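A few compounds are considered here, and "the series" means these few. Any claim that something is new, unique, unknown or untested is made for them only; others in the source may bear on it.

Compound 1 `CC(=NNC(=S)Nc1ccccc1F)c1ccccn1` was tested in an ADME assay on cells (Erythrocyte, Homo sapiens), read by hemolysis, with a stated time of 1 h; on this read-out lower numbers stand for stronger inhibition and higher numbers for weaker inhibition. In this assay compound 1 gives > 10000 nM, which is a limit of the assay rather than a number. Two related compounds were measured alongside it. Compound 2 `CC(=NNC(=S)Nc1ccc(I)cc1)c1ccccn1` gives > 10000 nM in this assay, again a limit. Compound 3 `CC(=NNC(=S)Nc1ccc(Cl)cc1)c1ccccn1` gives > 10000 nM in this assay, also a limit. The step from compound 2 to compound 3, a step that the two limits leave unreadable from compound 2 to compound 3, cannot be sized because of the limit of > 10000 nM in this assay, at which 3 of the 3 values shown sit. Compound 1 thus stands at the same limit as the other two, and none of the three can be ranked against another.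

Compound 4 `CC(=NNC(=S)Nc1ccccc1[N+](=O)[O-])c1ccccn1` is the compound still to be measured. It differs from compound 1 in one place: nitro in place of fluoro on an aromatic carbon. For the measured compounds named here, the only measured step, a step that the two limits leave unreadable from compound 2 to compound 3, concerns a change of a group on an aromatic carbon, but its size is hidden by the limits, so it offers no direction. Going by the values given here, with every value so far a limit, compound 4 is expected to sit near that limit as well, the estimated step being a step that the limit leaves unreadable from compound 1 to compound 4. Compound 4 is therefore estimated to give 20000 nM in this assay, with a range from 8000 nM to 60000 nM.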

Compound 4, half-maximal inhibitory concentration: > 10000 nM
Compound 4: a limit, no number (the forecaster's own chance of this, stated with the estimate: 85%); the middle value does not contradict the limit.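

No step can be read from compound 1 to compound 4 in this assay, because both values are limits rather than numbers: the limit of > 10000 nM in this assay, at which 4 of the 4 values shown sit.

The compounds shown leave open how these four compounds rank in this assay, and whether nitro in place of fluoro changes the read-out at all.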